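The compounds below may be only part of what the source reports. "The series", "measured", "known", "first", "only" and "open" are said of these compounds alone.

In a functional assay on DU-145 cells (Homo sapiens) for cytotoxicity, read by trypan blue exclusion, with a stated time of 96 h (a higher number here means a weaker inhibitor, a lower number a stronger inhibitor), the measured compounds stand as follows:

compound 1 `COc1ccccc1/C=C/S(=O)(=O)Cc1ccc(OC)c([N+](=O)[O-])c1`: 20000 nM
compound 2 `COc1ccc(CS(=O)(=O)/C=C/c2ccccc2OC)cc1N`: 7500 nM
compound 3 `COc1cc(OC)c(/C=C/S(=O)(=O)Cc2ccc(OC)cc2[N+](=O)[O-])c(OC)c1`: 20000 nM

Compound 1 and compound 3 are level at the digits printed, together the highest of the three numbers, and the difference between their two cores is not broken down here. From compound 1 to compound 2 the change is amino in place of nitro on an aromatic carbon, and the step it made is a 2.7-fold lower number from compound 1 to compound 2 (0.43 log units; beyond the scatter). Compound 4 `COc1ccc(CS(=O)(=O)/C=C/c2c(OC)cc(OC)cc2OC)c(N)c1` has not been measured in this assay; it differs from compound 3 by amino in place of nitro on an aromatic carbon. This is the same kind of change as that from compound 1 to compound 2, though the surroundings differ: in compound 2 the amino sits ortho to a methoxy group and meta to a large group, whereas in compound 4 it sits ortho to a large group and meta to a methoxy group. Going by the values given here, on the strength of the one earlier step, compound 4 is expected to show a 2.7-fold lower number from compound 3 to compound 4 (0.43 log units; beyond the scatter) against compound 3, because that earlier change gave a 2.7-fold lower number from compound 1 to compound 2 (0.43 log units; beyond the scatter). The estimate for compound 4 in this assay is therefore 7500 nM, expected to lie between 3000 nM and 20000 nM.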

Compound 4, half-maximal inhibitory concentration: 25 nM
Compound 4: the middle estimate sits 300-fold (2.48 log units) above what was measured, and the stated range ends above it.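

In this assay, amino in place of nitro on the core of compound 3 gave an 800-fold lower number from compound 3 to compound 4 (2.90 log units; beyond the scatter) and did not repeat the size of the earlier step: the same change on two cores in this assay, a 2.7-fold lower number (0.43 log units; beyond the scatter) from compound 1 to compound 2 and an 800-fold lower number (2.90 log units; beyond the scatter) from compound 3 to compound 4, 300-fold (2.48 log units) apart, beyond the scatter of two such steps. The change therefore lowered the number on both cores, but its size did not carry over from the core of compound 1 to the core of compound 3. Two pairs do not show which difference between the cores accounts for the gap, whether the methoxy groups or the place of the amino group, which in compound 4 is ortho to a large group, and they give no basis for predicting the size of the step on a third core.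

The compounds shown leave open how a hydroxyl group or an acetamide at the same place would compare with amino on the core of compound 4. They also leave open whether amino alone accounts for the low number of compound 4, or whether it depends on the three methoxy groups of that core.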